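A 2-methoxybenzyl group replaces a branched side chain

A few compounds are considered here, and "the series" means these few. Any claim that something is new, unique, unknown or untested is made for them only; others in the source may bear on it.

In a functional assay on the whole organism (arterial blood) with Rattus norvegicus as the target (on this read-out lower numbers stand for an effect already at smaller amounts and higher numbers for an effect only at larger amounts of compound), compound 1 `Cc1nc2cnccc2n1CC1CCN(C(=O)CC(C)c2ccccc2)CC1` gives 0.033 mg/kg, compound 2 `CCCC(CC(=O)N1CCC(Cn2c(C)nc3cnccc32)CC1)c1ccccc1` gives 0.0079 mg/kg and compound 3 `Cc1nc2cnccc2n1CC1CCN(C(=O)CC(C)(C)c2ccccc2)CC1` gives 0.012 mg/kg. Compound 3 thus stands with compound 2, a 1.5-fold higher number from compound 2 to compound 3 (0.18 log units; within the scatter), and apart from compound 1, a 2.8-fold lower number from compound 1 to compound 3 (0.44 log units; beyond the scatter). Compound 4 `COc1ccccc1CCC(=O)N1CCC(Cn2c(C)nc3cnccc32)CC1` differs from compound 3 by 2-methoxybenzyl in place of 1-methyl-1-phenylethyl on a saturated chain carbon bound to a carbonyl carbon. Going by the values given here, no measured compound carries 2-methoxybenzyl, so the evidence is indirect. The nearest guides are a 2.8-fold lower number from compound 1 to compound 3 (0.44 log units; beyond the scatter) and a 4.2-fold lower number from compound 1 to compound 2 (0.62 log units; beyond the scatter), both modest steps that added carbon to the chain. With 1-methyl-1-phenylethyl leaving, the lowering seen in the step to compound 3 may be lost. The expected change in this assay is modest and upward, a 2.5-fold higher number from compound 3 to compound 4 (0.40 log units; beyond the scatter). Compound 4 is estimated at 0.03 mg/kg, with an expected range of 0.008 mg/kg to 0.11 mg/kg.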

Compound 4, dose for 50% inhibition: 0.045 mg/kg
The estimate for compound 4 lay 1.5-fold (0.18 log units) below the measured number; the measured number falls inside the stated range.
By their numbers in this assay, from the lowest: compounds 2 and 3 (each within the scatter of the next); then compounds 1 and 4 (each within the scatter of the next).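

On this assay, the change to 2-methoxybenzyl on this saturated chain carbon bound to a carbonyl carbon gives a 3.8-fold higher number from compound 3 to compound 4 (0.57 log units; beyond the scatter) and, against the 1-phenylbutyl group, a 5.7-fold higher number from compound 2 to compound 4 (0.76 log units; beyond the scatter). Against the 1-phenylethyl group it gives a 1.4-fold higher number from compound 1 to compound 4 (0.13 log units; within the scatter), so here the new group matches the smallest of the earlier groups rather than the two larger ones. Nothing available explains these steps.

Because the methoxy group and the change in chain shape arrive together, the compounds shown cannot separate the two. On these data alone, a plain benzyl group at this place would leave the methoxy group out and remains open.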